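Cyano for Fluoro on a Fused Thiophene Ring

The source may hold more compounds than are shown below. What is called first, only, known or untested is meant among the compounds shown, and "the series" means these compounds.

Compound 1 `CC#C[C@@H](Cc1nnn[nH]1)c1ccc(OCc2ccc3sc(F)c(-c4ccccc4C)c3c2)cc1` was tested in a functional assay on cells for agonist activity at Free fatty acid receptor 1 (Homo sapiens), read by FLIPR and calcium flux (a higher number here means that more compound is needed for the effect, a lower number that less compound is needed), and gives 15 nM. Among the compounds with values here, of the two numbers measured so far, compound 1 has the lowest; its nearest neighbour is compound 2 `CC#C[C@@H](Cc1nnn[nH]1)c1ccc(OCc2ccc3sc(F)c(-c4ccc(OCCOC)cc4C)c3c2)cc1`, which in this assay gives 18 nM. Within the data shown here, the only measured step joins these two, a 1.2-fold higher number from compound 1 to compound 2 (0.08 log units; within the scatter), and it concerns a 2-methoxyethoxy group added on the aromatic carbon of the 2-methylphenyl group; it does not touch the fluorine atom of the shared core.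

Compound 3 `CC#C[C@@H](Cc1nnn[nH]1)c1ccc(OCc2ccc3sc(C#N)c(-c4ccccc4C)c3c2)cc1` differs from compound 1 in one place: cyano in place of fluoro on an aromatic carbon. Among the measured compounds shown here, no measured step involves this position, so the measured data give no direct guide to the size or direction of the change. The working expectation is therefore a step within the scatter, with some room for the number to move in either direction.

The estimated step from compound 1 to compound 3 in this assay is a 1.5-fold higher number from compound 1 to compound 3 (0.17 log units; within the scatter). Compound 3 is expected to give about 22 nM, within a range from 7 nM to 70 nM.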

Compound 3, half-maximal effective concentration: 16 nM
For compound 3 the middle estimate is 1.4-fold (0.14 log units) above the measured one, within the range that was stated.
By their numbers in this assay, from the lowest: compounds 1, 3 and 2 (each within the scatter of the next).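

In this assay, within the data shown here, the exchange of fluoro for cyano on this aromatic carbon, next to the ring sulfur, gives a 1.1-fold higher number from compound 1 to compound 3 (0.03 log units; within the scatter), the first measured step at this position. The entering cyano has 2 heavy atoms, a triple bond and 1 hydrogen-bond acceptor, whereas the leaving fluoro has 1 heavy atom and 0 hydrogen-bond acceptors, yet this difference does not separate the two compounds in this assay. No supporting measurement explains why these two groups give readings within the scatter of each other.

This is a single pair on a single background, so the compounds shown leave open whether the same exchange would read alike in compound 2, which carries the 2-methoxyethoxy group. They also leave open whether this carbon would accept groups of a different kind, such as an amine, a carboxylic acid or a longer chain, with a reading still within the scatter of compound 1.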